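Swapping a Fluorophenyl for a Trimethoxyphenyl

The source may hold more compounds than are shown below. What is called first, only, known or untested is meant among the compounds shown, and "the series" means these compounds.

Compound 1 `COc1cc(/C=C2\CN(S(=O)(=O)c3ccc(F)cc3)C/C(=C\c3cccc([N+](=O)[O-])c3)C2=O)cc(OC)c1OC` gives 3250 nM
Compound 2 `CC(=O)Nc1ccc(S(=O)(=O)N2C/C(=C\c3cccc([N+](=O)[O-])c3)C(=O)/C(=C/c3ccccc3F)C2)cc1` gives 8800 nM

For the measured compounds named here, in a functional assay on HepG2 cells (Homo sapiens) for cytotoxicity, read by MTT assay, with a stated time of 24 h (a lower number here means a stronger inhibitor, a higher number a weaker inhibitor), only two compounds have been measured so far. Compound 2 has the higher number of the pair at 8800 nM, while compound 1 sits at 3250 nM, a gap beyond the usual scatter.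

The next compound is compound 3 `COc1cc(/C=C2\CN(S(=O)(=O)c3ccc(NC(C)=O)cc3)C/C(=C\c3cccc([N+](=O)[O-])c3)C2=O)cc(OC)c1OC`, which is compound 2 with 3,4,5-trimethoxyphenyl in place of 2-fluorophenyl on a double-bonded chain carbon bound to a double-bonded ring carbon. Going by the values given here, no measured pair shows this single change alone, so the evidence is thin. Among the compounds with values here, the only guide is compound 1, which also carries 3,4,5-trimethoxyphenyl and gives 3250 nM, a lower number than that of compound 2.

A small drop in this assay is therefore expected, estimated as a 2.0-fold lower number from compound 2 to compound 3 (0.29 log units; within the scatter), and it may not clear the usual scatter. For compound 3 the expected value is 4500 nM (estimated range 1800 nM to 10000 nM).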

Compound 3, half-maximal inhibitory concentration: 3340 nM
The estimate for compound 3 lay 1.3-fold (0.13 log units) above the measured number, and the stated range covers the measured number.
By their numbers in this assay, from the lowest: compounds 1 and 3 (each within the scatter of the next); then compound 2.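

In this assay the exchange of 2-fluorophenyl for 3,4,5-trimethoxyphenyl on a double-bonded chain carbon bound to a double-bonded ring carbon can now be read as a single change, and it gives a 2.6-fold lower number from compound 2 to compound 3 (0.42 log units; beyond the scatter) as a modest step that clears the scatter. A change at a second place, acetamido in place of fluoro on an aromatic carbon, gives a 1.0-fold higher number from compound 1 to compound 3 (0.01 log units; within the scatter) and so does not separate these two groups when 3,4,5-trimethoxyphenyl is present. For the compounds shown here, nothing measured so far explains why either change has the effect it does.

Going by these compounds alone, with only two groups compared on that chain carbon, it remains open whether all three methoxy groups are needed, or whether an unsubstituted phenyl or a ring with a single methoxy group would give a similar number. Going by these compounds, it is also open whether acetamido and fluoro would still match with 2-fluorophenyl in place, and whether an amine or a carboxylic acid on that aromatic carbon would match them too.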